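The source may report more compounds than this note shows. Statements on the series, on what has been measured and on what is new or still open speak of the compounds shown alone.

Compound 1 `O=C1C(=O)N(CCCCn2cc(COc3cc(=O)oc4ccccc34)nn2)c2ccc(Br)cc21`, compound 2 `O=C1C(=O)N(CCCn2cc(COc3cc(=O)oc4ccccc34)nn2)c2ccc(F)cc21` and compound 3 `O=C1C(=O)N(CCCCn2cc(COc3cc(=O)oc4ccccc34)nn2)c2ccc(F)cc21` have been run in a functional assay on HCT-116 cells (Homo sapiens) for inhibition, read by sulforhodamine B assay, with a stated time of 48 h, tested at 50 uM; on this read-out higher numbers stand for more inhibition of growth at the one concentration tested and lower numbers for less inhibition of growth. In this assay compound 1 gives 59%, compound 2 gives 75% and compound 3 gives 67%. Compound 3 and compound 1 differ in one place, (bromo in place of fluoro on an aromatic carbon), and that step is a number 8 percentage points lower from compound 3 to compound 1 (within the scatter). Compound 2 and compound 3 differ in their cores; the difference between the two cores is not broken down here. Their values in this assay lie within the usual scatter of each other, whereas the gap from compound 2 to compound 1 lies beyond it.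

Compound 4 `O=C1C(=O)N(CCCn2cc(COc3cc(=O)oc4ccccc34)nn2)c2ccc(Br)cc21` has not yet been measured. It differs from compound 2 by bromo in place of fluoro on an aromatic carbon; this is the same change as from compound 3 to compound 1, now made on the core of compound 2. For the measured compounds named here, the step from compound 2 to compound 4 in this assay is expected to be a number 8 percentage points lower from compound 2 to compound 4 (within the scatter), set beside a number 8 percentage points lower from compound 3 to compound 1 (within the scatter), because a number 8 percentage points lower from compound 3 to compound 1 (within the scatter) is the only measured instance of this change. The expectation also rests on the value of compound 2, 75%. For compound 4 in this assay the estimated value is 67%, with 55% to 79% as the expected range.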

Compound 4, percent growth inhibition at one concentration: 66%
For compound 4 the middle estimate is 1 percentage points above the measured one; the range from low to high includes it.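

Bromo in place of fluoro on the aromatic carbon can now be read on two cores in this assay, and the new step is a number 9 percentage points lower from compound 2 to compound 4 (within the scatter). Set beside the earlier step, the two agree: the same change on two cores in this assay, a number 8 percentage points lower (within the scatter) from compound 3 to compound 1 and a number 9 percentage points lower (within the scatter) from compound 2 to compound 4, 1 percentage points apart, within the scatter of two such steps. This shows that the change carried across these two cores without a detectable difference, but each step lies within the scatter, so the pair does not establish that the change itself lowers growth inhibition, and two cores say nothing about how it would behave on any other core.

The compounds shown carry only fluoro or bromo at this aromatic carbon, which leaves open how chloro, methoxy, a nitrile or plain hydrogen would read there. Going by these compounds, a longer chain between the two ring systems also remains open, as does whether these readings at a single concentration would hold across a full concentration range.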